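The compounds below may be only part of what the source reports. "The series", "measured", "known", "first", "only" and "open" are said of these compounds alone.

In a functional assay on U-937 cells (Homo sapiens) for antiproliferative activity, read by MTT assay, with a stated time of 24 h (a lower number here means a stronger inhibitor, a higher number a weaker inhibitor), the three measured amides sit close together: compound 1 `CCCCc1oc2ccccc2c1C(=O)c1ccc(OCC(N)=O)cc1` gives 42200 nM, compound 2 `CCCCc1oc2ccccc2c1C(=O)c1ccc(OCC(=O)N2CCOCC2)cc1` gives 45400 nM, and compound 3 `CCCCc1oc2ccccc2c1C(=O)c1ccc(OCC(=O)Nc2cccc(OC)c2)cc1` gives 24200 nM. Compound 3 therefore stands within the scatter of both others. Compound 4 `CCCCc1oc2ccccc2c1C(=O)c1ccc(OCC(=O)N[C@@H](C)c2ccccc2)cc1` carries 1-phenylethyl in place of 3-methoxyphenyl on an amide-type nitrogen. The bearing steps are a 1.7-fold lower number from compound 1 to compound 3 (0.24 log units; within the scatter), a 1.9-fold lower number from compound 2 to compound 3 (0.27 log units; within the scatter) and a 1.1-fold higher number from compound 1 to compound 2 (0.03 log units; within the scatter), and none leaves the scatter. With only these three compounds as evidence, no step beyond the scatter is expected in this assay. The expected step is a 1.2-fold higher number from compound 3 to compound 4 (0.06 log units; within the scatter). The estimated value for compound 4 is 28000 nM, with an expected range of 12000 nM to 60000 nM.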

Compound 4, half-maximal inhibitory concentration: 33800 nM
Compound 4: middle estimate off by 1.2-fold (0.08 log units), on the low side; the measured number falls inside the stated range.
By their numbers in this assay, from the lowest: compounds 3, 4, 1 and 2 (each within the scatter of the next).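

Putting 1-phenylethyl in place of 3-methoxyphenyl on the amide-type nitrogen loses the methoxy oxygen and adds a defined stereocentre, yet in this assay the change stays within the scatter (a 1.4-fold higher number from compound 3 to compound 4 (0.15 log units; within the scatter)). Compound 4 also stays within the scatter of the simpler amides (a 1.2-fold lower number from compound 1 to compound 4 (0.10 log units; within the scatter); a 1.3-fold lower number from compound 2 to compound 4 (0.13 log units; within the scatter)), so this position has now taken two different aryl-bearing groups with no step beyond the scatter. Nothing available explains this flat response.

On these data alone, whether the opposite enantiomer of 1-phenylethyl would read differently remains open. So does whether a carboxylic acid or a dimethylaminoethyl amide here would leave the scatter.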